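The source may hold more compounds than are shown below. What is called first, only, known or untested is meant among the compounds shown, and "the series" means these compounds.

Of the compounds shown here, two from this series have been tested so far in a functional assay on HeLa cells (Homo sapiens) for inhibition; on this read-out lower numbers stand for stronger inhibition and higher numbers for weaker inhibition. Compound 1 `CC(C)=CCC/C(C)=C/C[C@]12C[C@@H](CC=C(C)C)C(C)(C)[C@](CC=C(C)C)(C(=O)C(C(=O)c3ccc(O)c(O)c3)=C1O)C2=O` gives 11.7 ug/mL in this assay. Compound 2 `CC(C)=CCC/C(C)=C/C[C@@H]1C[C@]2(CC=C(C)C)C(=O)[C@@](CC=C(C)C)(C(=O)C(C(=O)c3ccc(O)c(O)c3)=C2O)C1(C)C` is a close relative; in this assay compound 2 reaches only > 20 ug/mL, which is a limit of the assay rather than a number, so the strength of compound 2 is known only as lying beyond (the limit of > 20 ug/mL in this assay, at which 1 of the 2 values shown sits). Compound 3 `CC(C)=CCC/C(C)=C/C[C@@H]1C[C@]2(C/C=C(\C)CCC=C(C)C)C(=O)[C@@](CC=C(C)C)(C(=O)C(C(=O)c3ccc(O)c(O)c3)=C2O)C1(C)C` is not yet measured. It differs from compound 2 in one place: 3-methylbut-2-en-1-yl in place of hydrogen on a saturated chain carbon bound to a double-bonded chain carbon. For the measured compounds named here, no measured pair with exactly this change is available, so the size and direction of the step from compound 2 to compound 3 cannot be read from the data. With compound 2 known only as a limit, a step of any clear size is not expected, and the estimated shift a step that the limit leaves unreadable from compound 2 to compound 3 is small. Compound 3 is therefore expected to give about 25 ug/mL, within a range from 10 ug/mL to 60 ug/mL.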

Compound 3, half-maximal inhibitory concentration: 8.09 ug/mL
Beside the measured number, compound 3's estimate is 3.1-fold (0.49 log units) above it, and the stated range ends above it.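

In this assay, putting 3-methylbut-2-en-1-yl in place of hydrogen on a saturated chain carbon bound to a double-bonded chain carbon extends a 3-methylbut-2-en-1-yl chain to 3,7-dimethylocta-2,6-dien-1-yl and gives an at least 2.4-fold lower number from compound 2 to compound 3 (0.39 log units; beyond the scatter), so this place accepts the longer chain and the change registers beyond the scatter. The value of compound 2, > 20 ug/mL, is a limit of this assay and not a number: the limit of > 20 ug/mL in this assay, at which 1 of the 3 values shown sits. The same comparison with the other measured compound gives a 1.4-fold lower number from compound 1 to compound 3 (0.16 log units; within the scatter), so those two cannot be told apart in this assay.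

The full size of the gain over the limit cannot be read. Also open, from the compounds shown here alone, is how this place would respond to a plain ethyl group, or to a chain ending in an amine or a carboxylic acid.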